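Changing the Side Chain on the Sugar-Like Ring

The source may hold more compounds than are shown below. What is called first, only, known or untested is meant among the compounds shown, and "the series" means these compounds.

Compound 1 `CCCSc1nc(N[C@@H]2C[C@H]2c2ccc(F)c(F)c2)c2nnn([C@@H]3C[C@H](OC(=O)CC)[C@@H](O)[C@H]3O)c2n1`: 44.5%
Compound 2 `CCCSc1nc(N[C@@H]2C[C@H]2c2ccc(F)c(F)c2)c2nnn([C@@H]3C[C@H](OC(=O)OCC)[C@@H](O)[C@H]3O)c2n1`: 42.6%

In a functional assay on the whole organism (strain Sprague-Dawley) for inhibition, with Rattus norvegicus as the target, with a stated time of 0.5 h, at a dose of 5 mg/kg by the oral route (a lower number here means less inhibition, a higher number more inhibition at the dose given (going by the name of the read-out)), compound 1 gives 44.5% and compound 2 gives 42.6%. Compound 2 has the lower of the two numbers, yet a number 1.9 percentage points lower from compound 1 to compound 2 (within the scatter) falls within the scatter, so the two cannot be told apart. Compound 3 `CCCSc1nc(N[C@@H]2C[C@H]2c2ccc(F)c(F)c2)c2nnn([C@@H]3C[C@H](OCCOC(=O)CCC)[C@@H](O)[C@H]3O)c2n1` carries a different change: 2-((propylcarbonyl)oxy)ethyl in place of ethoxycarbonyl on an oxygen on a saturated carbon. Among the measured compounds shown here, the only measured step swapped ethoxy for ethyl on a carbonyl carbon and barely moved the read-out; no measured step matches the present, larger change. Compound 3 is therefore expected to show a number 2.6 percentage points lower from compound 2 to compound 3 (within the scatter), a step not clearly beyond the scatter, with a wide range. The estimate for compound 3 is 40%, between 22% and 58%.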

Compound 3, a percentage reported as inhibition, in the whole organism at one dose (the size of the read-out at that dose, not a potency): "not active" (no number reported)
No number was reported for compound 3, and the estimate cannot be compared.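

Among the compounds shown here, compound 3 is reported as "not active" with no number, so no step from compound 2 to compound 3 can be read. The compounds shown leave open how 2-((propylcarbonyl)oxy)ethyl in place of ethoxycarbonyl changes the read-out. No available evidence bears on this result.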